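Furan-2-yl in Place of Phenyl: What Compound 4 Might Show

A few compounds are considered here, and "the series" means these few. Any claim that something is new, unique, unknown or untested is made for them only; others in the source may bear on it.

Of the compounds shown here, three built on a shared core have been tested in a functional assay for inhibition of sodium/hydrogen exchanger (Oryctolagus cuniculus); a lower number here means a stronger inhibitor, a higher number a weaker inhibitor. Compound 1 `Cc1cc(Br)c(S(C)(=O)=O)cc1C(=O)N=C(N)N` gives 12 nM. Compound 2 `Cc1cc(-c2ccc(Cl)cc2)c(S(C)(=O)=O)cc1C(=O)N=C(N)N` gives 45 nM, and compound 3 `Cc1cc(-c2ccccc2)c(S(C)(=O)=O)cc1C(=O)N=C(N)N` gives 19 nM. Among these numbers compound 3 has the second highest value: its nearest neighbour is compound 1, with a gap that stays within the scatter, while the step of a 2.4-fold lower number from compound 2 to compound 3 (0.37 log units; beyond the scatter) lies beyond the scatter.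

Compound 4 `Cc1cc(-c2ccco2)c(S(C)(=O)=O)cc1C(=O)N=C(N)N` differs from compound 3 in a single place: furan-2-yl in place of phenyl on an aromatic carbon.

Within the data shown here, two measured steps bear on this change, though neither reproduces it. The step of a 1.6-fold higher number from compound 1 to compound 3 (0.20 log units; within the scatter) shows that replacing bromo with phenyl hardly moved the number. The step of a 2.4-fold lower number from compound 2 to compound 3 (0.37 log units; beyond the scatter) shows a modest movement when the chloro on the phenyl ring was removed. Swapping one aromatic ring for a smaller one carrying an oxygen has no direct precedent here, so the expectation is for a step of at most modest size, most likely within the scatter, with no clear direction.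

Compound 4 is therefore expected to give 22 nM, within a range from 8 nM to 60 nM. The expected step is a 1.2-fold higher number from compound 3 to compound 4 (0.06 log units; within the scatter).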

Compound 4, half-maximal inhibitory concentration: 16 nM
Compound 4: middle estimate off by 1.4-fold (0.14 log units), on the high side; the range from low to high includes it.
By their numbers in this assay, from the lowest: compounds 1, 4 and 3 (each within the scatter of the next); then compound 2.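

In this assay, a five-membered aromatic ring with one hetero atom now sits ortho to a methylsulfonyl group, and a 1.2-fold lower number from compound 3 to compound 4 (0.07 log units; within the scatter) stays within the scatter, as does a 1.3-fold higher number from compound 1 to compound 4 (0.12 log units; within the scatter) on the change from the bromo group. Furan-2-yl, phenyl and bromo therefore cannot be told apart at this position, even though they differ in ring size, in atom type and in the presence of a hydrogen-bond acceptor. Compound 2 alone stands apart among the four, since a 2.8-fold lower number from compound 2 to compound 4 (0.45 log units; beyond the scatter) lies beyond the scatter, as do its steps to compound 1 and compound 3, and no measurement at hand accounts for any of this.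

The compounds shown leave open whether this insensitivity extends to groups of another kind at the same position, such as an amine, a carboxylic acid or a longer alkyl chain. They also leave open whether furan-3-yl would match furan-2-yl, and whether a chloro group on the furan ring would bring a rise like the one seen with 4-chlorophenyl.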